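A few compounds are considered here, and "the series" means these few. Any claim that something is new, unique, unknown or untested is made for them only; others in the source may bear on it.

Measured compounds:
- compound 1, `Cc1cc(NC(=O)Cn2nnc(-c3cccc(Cl)c3)n2)n(C2CCCCC2)n1`: 89%
- compound 2, `Cc1cc(NC(=O)Cn2nnc(-c3ccc(Cl)c(Cl)c3)n2)n(C2CCCCC2)n1`: 84%

Both were run in an assay on HEK293 cells for activation of Kir3.1/Kir3.2 (Homo sapiens), read by thallium flux; on this read-out higher numbers stand for larger maximal responses and lower numbers for smaller maximal responses. Compound 2 stands lowest of the two numbers recorded, with compound 1 as its nearest neighbour; the step of a number 5 percentage points lower from compound 1 to compound 2 (within the scatter) lies within the scatter, so the two values are not distinguished.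

Compound 3, `Cc1cc(NC(=O)Cn2nnc(-c3cc(Cl)cc(Cl)c3)n2)n(C2CCCCC2)n1`, is not yet measured. Its change from compound 2 is 3,5-dichlorophenyl in place of 3,4-dichlorophenyl on an aromatic carbon, on an aromatic carbon of a five-membered aromatic ring with 4 nitrogen. Going by the values given here, no measured step moves a chlorine from one position of the phenyl ring to another; the only step available, a number 5 percentage points lower from compound 1 to compound 2 (within the scatter), shows that adding a chlorine on that ring left the maximal response essentially unchanged. On this basis no step beyond the scatter is expected in this assay for compound 3.

The estimated value for compound 3 in this assay is 82%, expected to fall between 65% and 97%. The step of a number 2 percentage points lower from compound 2 to compound 3 (within the scatter) is expected to stay within the scatter.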

Compound 3, largest response reached (Emax), in percent of the reference or control that the assay uses: 82%
The estimate for compound 3 equals the measured number at the digits printed; the measured number falls inside the stated range.
By their numbers in this assay, from the lowest: compounds 3, 2 and 1 (each within the scatter of the next).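

In this assay, 3,5-dichlorophenyl in place of 3,4-dichlorophenyl on the aromatic carbon of the five-membered aromatic ring with 4 nitrogen gives a number 2 percentage points lower from compound 2 to compound 3 (within the scatter), so moving one chlorine on this phenyl ring does not separate the two isomers. Chloro in place of hydrogen in the 3,5-dichlorophenyl arrangement gives a number 7 percentage points lower from compound 1 to compound 3 (within the scatter), so this second way of adding a chlorine also leaves the maximal response undistinguished. Nothing available explains why these chlorine changes leave the read-out unresolved.

Still open, from the compounds shown here alone, is whether anything other than chlorine on this phenyl ring, such as a methoxy group, a primary amine or a carboxylic acid, would give a step beyond the scatter. Also open, going by these compounds, is whether a pyridine ring in place of the phenyl ring would do so.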